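From a Nitrophenyl to a Chlorophenyl Hydrazone

The source may hold more compounds than are shown below. What is called first, only, known or untested is meant among the compounds shown, and "the series" means these compounds.

Compound 2 `CC1=CC[C@@H]([C@@](C)(O)CCCC(C)(C)NC(=S)N/N=C\c2ccc([N+](=O)[O-])cc2)CC1` carries a 4-nitrophenyl on a carbon with a double bond to nitrogen. In a functional assay on PCO3 cells (Homo sapiens) for cytotoxicity, read by sulforhodamine B assay (on this read-out higher numbers stand for weaker inhibition of growth and lower numbers for stronger inhibition of growth), compound 2 gives 18100 nM. Within the data shown here, the only other measured compound, compound 1 `CC1=CC[C@@H]([C@@](C)(O)CCCC(C)(C)NC(=S)NN)CC1`, has no 4-nitrophenyl; in this assay compound 1 gives 26800 nM, and the two values lie within the scatter of each other. Compound 3 `CC1=CC[C@@H]([C@@](C)(O)CCCC(C)(C)NC(=S)N/N=C\c2ccccc2Cl)CC1` differs from compound 2 by 2-chlorophenyl in place of 4-nitrophenyl on a carbon with a double bond to nitrogen. Among the measured compounds shown here, no measured pair shows this change, so the expected step of a 1.0-fold lower number from compound 2 to compound 3 (0.00 log units; within the scatter) is small, not beyond the scatter. Compound 3 is estimated at 18000 nM, between 6000 nM and 50000 nM.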

Compound 3, concentration for 50% growth inhibition: 18800 nM
Compound 3: the middle estimate sits 1.0-fold (0.02 log units) below what was measured; low and high end bracket the measured number.
By their numbers in this assay, from the lowest: compounds 2, 3 and 1 (each within the scatter of the next).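

In this assay, 2-chlorophenyl in place of 4-nitrophenyl on a carbon with a double bond to nitrogen gives a 1.0-fold higher number from compound 2 to compound 3 (0.02 log units; within the scatter) and so does not separate the two groups at this position. The group of 9 heavy atoms in place of one nitrogen atom, on an amide-type nitrogen, gives a 1.4-fold lower number from compound 1 to compound 3 (0.15 log units; within the scatter) and is likewise not separated from compound 1. Nothing measured here offers an explanation for these results. On these data alone, whether an amine or a carboxylic acid on that phenyl ring would shift the number beyond the scatter remains open.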